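Swapping Nitro for Amino on a Two-Compound Series

This account rests on a few compounds, and the source may have more. Where it says the series, first, only, none or still open, it means among the compounds named here.

In a functional assay on KYSE-450 cells (Homo sapiens) for inhibition, read by CCK-8 assay, with a stated time of 48 h (on this read-out higher numbers stand for weaker inhibition and lower numbers for stronger inhibition), compound 1 `COc1ccc(CN(C(=O)CSC(=S)N2CCN(C(=O)OC(C)(C)C)CC2)c2cc(OC)c(OC)c(OC)c2)cc1Br` gives 1850 nM as the higher number. Going by the values given here, compound 2 `COc1ccc(CN(C(=O)CSC(=S)N2CCN(C(=O)OC(C)(C)C)CC2)c2cc(OC)c(OC)c(OC)c2)cc1[N+](=O)[O-]` gives 810 nM and so stands lowest of the two numbers so far. Compound 3 `COc1ccc(CN(C(=O)CSC(=S)N2CCN(C(=O)OC(C)(C)C)CC2)c2cc(OC)c(OC)c(OC)c2)cc1N` keeps the shared core and carries amino in place of nitro on an aromatic carbon, ortho to a methoxy group and meta to a large group (amino in place of nitro on an aromatic carbon). Among the compounds with values here, only one measured step bears on this place, the exchange of bromo for nitro on that same carbon, which is a 2.3-fold lower number from compound 1 to compound 2 (0.36 log units; beyond the scatter) and counts as modest. It says nothing direct about amino. A step of similar or smaller size is therefore expected in this assay with no firm direction. The estimated change is a 1.1-fold lower number from compound 2 to compound 3 (0.03 log units; within the scatter) and remains uncertain. Compound 3 is expected at 750 nM with an estimated range from 220 nM to 2500 nM in this assay on this reasoning.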

Compound 3, half-maximal inhibitory concentration: 208 nM
The estimate for compound 3 lay 3.6-fold (0.56 log units) above the measured number; measured number below the stated range.
By their numbers in this assay, from the lowest: compound 3; then compound 2; then compound 1.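

The carbon ortho to a methoxy group proves more responsive than the bromo-to-nitro exchange alone suggested, and amino gives the lowest number of the three groups in this assay. The exchange of nitro for amino is the larger of the two single changes involving nitro (a 3.9-fold lower number from compound 2 to compound 3 (0.59 log units; beyond the scatter)), and the full distance from bromo to amino is wider still (an 8.9-fold lower number from compound 1 to compound 3 (0.95 log units; beyond the scatter)). No measurement shown here accounts for this order.

The three compounds leave open which feature of amino matters, since its hydrogen-bond donor is only one of several ways in which it differs from nitro. Nor do they show whether a hydroxyl group, a methylamino group or an acetamide on the same carbon would continue the trend or reverse it.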